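Working notes: from compound 3 to compound 4

A few compounds are considered here, and "the series" means these few. Any claim that something is new, unique, unknown or untested is made for them only; others in the source may bear on it.

Measured so far in an ADME assay on HCT-116 cells (Homo sapiens) for cytotoxicity, read by CellTiter-Glo, with a stated time of 72 h; on this read-out lower numbers stand for stronger inhibition and higher numbers for weaker inhibition:
Compound 1 `CC1CCN(C2CCN(S(=O)(=O)c3cccc(-c4ccccc4F)c3)CC2)CC1` gives > 5000 nM, a limit.
Compound 2 `Cc1cccc(S(=O)(=O)N2CCC(N3CCC(C)CC3)CC2)c1` gives > 5000 nM, a limit.
Compound 3 `CC1CCN(C2CCN(S(=O)(=O)c3cccc(-c4ccccc4C(F)(F)F)c3)CC2)CC1` gives > 5000 nM, a limit.

Compound 3 has no number in this assay, only a limit, and the whole series stands at the limit of > 5000 nM in this assay, at which 3 of the 3 values shown sit. The next compound is compound 4 `Cc1cc(C)cc(-c2cccc(S(=O)(=O)N3CCC(N4CCC(C)CC4)CC3)c2)c1`, and the change to it is 3,5-dimethylphenyl in place of 2-(trifluoromethyl)phenyl on an aromatic carbon. In words, 3,5-dimethylphenyl replaces 2-(trifluoromethyl)phenyl on an aromatic carbon, meta to a large group.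

Within the data shown here, three measured steps bear on this change. Placing methyl where 2-fluorophenyl stood is a step that the two limits leave unreadable from compound 1 to compound 2. Placing trifluoromethyl where fluoro stood is a step that the two limits leave unreadable from compound 1 to compound 3. Placing 2-(trifluoromethyl)phenyl where methyl stood is a step that the two limits leave unreadable from compound 2 to compound 3. None of the three has a size that can be carried over to the 3,5-dimethylphenyl group, and no direction can be drawn from them.

The expectation therefore starts from compound 3, whose reading of > 5000 nM is again a limit. The expected outcome is a step that the limit leaves unreadable from compound 3 to compound 4, with no readable size or direction anticipated. Most likely the assay again reports a limit. Compound 4 is estimated at 7000 nM, with an expected range from 3000 nM to 20000 nM.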

Compound 4, half-maximal inhibitory concentration: > 5000 nM
Compound 4: no number, only a limit; the forecaster's own chance of this, stated with the estimate: 85%; the middle value does not contradict the limit.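

In this assay compound 4 gives > 5000 nM, again a limit and not a number. Among these compounds, no step among compound 1, compound 2, compound 3 and compound 4 can therefore be read. The compounds shown leave open how these groups on the aromatic carbon rank against one another, as the whole series sits at one limit: the limit of > 5000 nM in this assay, at which 4 of the 4 values shown sit.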